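The compounds below may be only part of what the source reports. "The series", "measured", "known", "first", "only" and "open" are said of these compounds alone.

Of the compounds shown here, three sharing one core have been measured in a functional assay on cells for positive allosteric modulation of G-protein coupled receptor 68 (Homo sapiens), read by a luciferase reporter and cAMP accumulation, with a stated time of 30 min, at pH 6.8 and pH 8.3, in the presence of a further agent that is not named here; on this read-out higher numbers stand for higher potency (the scale is a negative logarithm) and lower numbers for lower potency. Compound 1 `Nc1nc(NCc2ccccc2F)nc(-c2ccccc2CO)n1` gives 4.27. Compound 2 `Nc1nc(NCc2ccccc2Cl)nc(-c2ccccc2CO)n1` gives 5.07, and compound 3 `Nc1nc(NCc2ccc(Cl)cc2)nc(-c2ccccc2CO)n1` gives 5.22, the highest of the three numbers, though its gap to compound 2 lies within the scatter. The measured steps were a number 0.80 log units higher from compound 1 to compound 2 (beyond the scatter), a number 0.95 log units higher from compound 1 to compound 3 (beyond the scatter) and a number 0.15 log units higher from compound 2 to compound 3 (within the scatter). Compound 4 `Cc1ccc(CNc2nc(N)nc(-c3ccccc3CO)n2)cc1` differs from compound 3 by methyl in place of chloro on an aromatic carbon. Going by the values given here, no measured step exchanges chloro for methyl; the one change that kept chloro but moved it, a number 0.15 log units higher from compound 2 to compound 3 (within the scatter), stayed within the scatter, while the halogen exchange a number 0.80 log units higher from compound 1 to compound 2 (beyond the scatter) was modest. A small step at most is therefore expected: a number 0.22 log units lower from compound 3 to compound 4 (within the scatter). Compound 4 is estimated at 5, between 4.4 and 5.6.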

Compound 4, negative logarithm of the antagonist equilibrium constant: 4.38
Estimate against measurement, compound 4: 0.62 log units above, and the stated range ends above it.
By their numbers in this assay, from the lowest: compounds 1 and 4 (each within the scatter of the next); then compounds 2 and 3 (each within the scatter of the next).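

Exchanging chloro for methyl on this aromatic carbon, para to a large group, replaces one heavy atom with one heavy atom, yet in this assay it gives a number 0.84 log units lower from compound 3 to compound 4 (beyond the scatter). The change from the 2-chlorobenzyl group gives a number 0.69 log units lower from compound 2 to compound 4 (beyond the scatter), while the change from the 2-fluorobenzyl group gives a number 0.11 log units higher from compound 1 to compound 4 (within the scatter), so here both chloro compounds stand clear of the two without chlorine. Nothing available explains why chloro and methyl differ here. Still open, from the compounds shown here alone, is whether bromo, methoxy or trifluoromethyl at this carbon would match chloro or fall to the level of methyl.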